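Estimating Compound 3 from a Single Measured Step

A few compounds are considered here, and "the series" means these few. Any claim that something is new, unique, unknown or untested is made for them only; others in the source may bear on it.

- compound 1 `CN(C[C@H]1Cc2ncccc2CN1)[C@H]1CCCc2cccnc21` gives 95%
- compound 2 `CCN(CC)CCCCN(C[C@H]1Cc2ncccc2CN1)[C@H]1CCCc2cccnc21` gives 80%

Both numbers come from an ADME assay on microsomes from liver (Homo sapiens) for metabolic stability, using NADPH, with a stated time of 10 min (a higher number here means that more of the compound is left, a lower number that less of the compound is left), where compound 2 holds the lower of the two values. Compound 3 `c1cnc2c(c1)CN[C@@H](CN(CCCC1CCNCC1)[C@H]1CCCc3cccnc31)C2` has not yet been measured. Its change from compound 2 is piperidin-4-yl in place of (diethylamino)methyl on a saturated chain carbon, three bonds along the chain from an amine nitrogen. Cut one bond further out, 4-(diethylamino)butyl gives way to 3-(piperidin-4-yl)propyl.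

Within the data shown here, no measured step exchanges these two groups, so the evidence is thin. The nearest guide is the step that brought in the whole 3-(diethylamino)propyl group, a number 15 percentage points lower from compound 1 to compound 2 (beyond the scatter). The present change replaces only part of that group, so no shift beyond the scatter is expected. The expected step is a number 2 percentage points higher from compound 2 to compound 3 (within the scatter). For compound 3 the estimated value is 82%, with an expected range from 68% to 94%.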

Compound 3, percent of the compound remaining: 100%
Compound 3: middle estimate off by 18 percentage points, on the low side, and the stated range ends below it.
By their numbers in this assay, from the lowest: compound 2; then compounds 1 and 3 (each within the scatter of the next).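

In this assay, piperidin-4-yl in place of (diethylamino)methyl on a saturated chain carbon, three bonds along the chain from an amine nitrogen, gives a number 20 percentage points higher from compound 2 to compound 3 (beyond the scatter), so two groups with the same heavy-atom count are not interchangeable at this place. The long chain alone does not set compound 2 apart from compound 1, since the chain ending in the ring gives a number 5 percentage points higher from compound 1 to compound 3 (within the scatter), which points to the end group as what matters among these three compounds. Nothing shown here accounts for the difference between the two end groups.

As far as these compounds go, it remains open whether the ring or its free amine hydrogen makes the difference, which a 1-methylpiperidin-4-yl or an open-chain secondary amine could separate. From the compounds shown here alone, whether a pyrrolidine or a shorter chain to the piperidine would behave alike also stays unknown.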